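This account rests on a few compounds, and the source may have more. Where it says the series, first, only, none or still open, it means among the compounds named here.

Measured in a functional assay on A2780 cells (Homo sapiens) for antiproliferative activity, read by MTT assay, with a stated time of 72 h; on this read-out higher numbers stand for weaker inhibition and lower numbers for stronger inhibition:
Compound 1 `COc1ccc(C2CC(c3ccccc3)=NN2C(=O)c2cc3ccccc3o2)cc1OC`: 6.89 ug/mL
Compound 2 `COc1ccc(C2CC(c3ccc(F)cc3)=NN2C(=O)c2cc3ccccc3o2)cc1`: 23 ug/mL
Compound 3 `O=C(c1cc2ccccc2o1)N1N=C(c2ccc(F)cc2)CC1c1ccc([N+](=O)[O-])cc1`: > 50 ug/mL (a limit of the assay, not a number)

Compound 3 stands at the weak end of this small set, and only a limit is known for it: the limit of > 50 ug/mL in this assay, at which 1 of the 3 values shown sits. The next compound to be measured, compound 4 `COc1ccc(C2CC(c3ccc(F)cc3)=NN2C(=O)c2cc3ccccc3o2)cc1OC`, has 3,4-dimethoxyphenyl in place of 4-nitrophenyl on a saturated ring carbon. The measured step that bears most directly on this change is an at least 2.1-fold higher number from compound 2 to compound 3 (0.33 log units; beyond the scatter), with nitro in place of methoxy on an aromatic carbon. Compound 4 gives up the nitro group again, so that step is expected to run in reverse, towards a lower number in this assay. On these data alone, its size stays open at the compound 3 end, since that end is a limit. Two further values help to place the result. Compound 1, which carries the same 3,4-dimethoxyphenyl group, gives 6.89 ug/mL. Compound 2, which carries the same 4-fluorophenyl group, gives 23 ug/mL. A clear gain beyond the scatter is therefore expected: an at least 4.1-fold lower number from compound 3 to compound 4 (0.61 log units; beyond the scatter). Compound 4 is estimated at 12 ug/mL, with an expected range from 5 ug/mL to 30 ug/mL.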

Compound 4, half-maximal inhibitory concentration: > 50 ug/mL
Compound 4 ended at the assay's limit; the forecaster's own chance of this, stated with the estimate: 5%; middle value at least 4.1-fold (0.61 log units) away from the limit.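

In this assay, compound 4 sits at a limit of the assay and not at a number, and compound 3 does too, so the step between them cannot be read and the two groups on the saturated ring carbon cannot be ranked: the limit of > 50 ug/mL in this assay, at which 2 of the 4 values shown sit.

What compound 4 adds shows up in its other two steps. Methoxy in place of hydrogen on an aromatic carbon gives an at least 2.1-fold higher number from compound 2 to compound 4 (0.33 log units; beyond the scatter), so the 3,4-dimethoxyphenyl group on this saturated ring carbon does not bring a gain over the single methoxy of compound 2 when the 4-fluorophenyl group is present. Fluoro in place of hydrogen on an aromatic carbon gives an at least 7.2-fold higher number from compound 1 to compound 4 (0.86 log units; beyond the scatter), so the same 3,4-dimethoxyphenyl group reads very differently depending on the aromatic ring at the other carbon, and its effect cannot be judged apart from that ring.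

On these data alone, both steps have only a lower bound, so how far compound 4 lies past the limit, and which of the two changes costs more, remains open. Also open, as far as these compounds go, is how this 3,4-dimethoxyphenyl group would read with a hydroxyl or an amine in place of the fluoro on that ring.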